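Swapping the phenoxy cap on a peptide ketone

A few compounds are considered here, and "the series" means these few. Any claim that something is new, unique, unknown or untested is made for them only; others in the source may bear on it.

Compound 2 `CC(C)[C@H](NC(=O)COc1cccc2ccccc12)C(=O)N[C@@H](CC(=O)O)C(=O)COc1ccc(C(N)=O)cc1` is the starting point. In a functional assay on Jurkat cells (Homo sapiens) (on this read-out higher numbers stand for weaker inhibition and lower numbers for stronger inhibition), compound 2 gives only a limit, > 100000 nM, and not a number. Two close relatives sit beside it. Compound 1 `CC(C)[C@H](NC(=O)COc1cccc2ccccc12)C(=O)N[C@@H](CC(=O)O)C(=O)COC(=O)c1c(Cl)cccc1Cl` gives 10600 nM in this assay. Compound 3 `CC(C)[C@H](NC(=O)COc1cccc2ccccc12)C(=O)N[C@@H](CC(=O)O)C(=O)COc1cccc(F)c1` also gives only a limit in this assay, > 100000 nM. The change that leads to compound 4 `CC(C)[C@H](NC(=O)COc1cccc2ccccc12)C(=O)N[C@@H](CC(=O)O)C(=O)COc1c(F)c(F)cc(F)c1F` is 2,3,5,6-tetrafluorophenyl in place of 4-carbamoylphenyl on an oxygen on a saturated carbon. Within the data shown here, the steps that bear on it are an at least 9.4-fold higher number from compound 1 to compound 2 (0.97 log units; beyond the scatter) and an at least 9.4-fold higher number from compound 1 to compound 3 (0.97 log units; beyond the scatter), while a step that the two limits leave unreadable from compound 2 to compound 3. Two of the three values sit at the limit of > 100000 nM in this assay, at which 2 of the 3 values shown sit, so the step is expected to be an at least 1.2-fold lower number from compound 2 to compound 4 (0.09 log units; that floor lies within the scatter), most likely ending again at a limit rather than a number. Compound 4 is therefore estimated at 80000 nM, within a range from 15000 nM to 300000 nM.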

Compound 4, half-maximal inhibitory concentration: 4500 nM
For compound 4 the middle estimate is 18-fold (1.25 log units) above the measured one, and the stated range ends above it.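

On the oxygen on a saturated carbon, 2,3,5,6-tetrafluorophenyl turns a silent cap into a measurable one in this assay, with an at least 22-fold lower number from compound 2 to compound 4 (1.34 log units; beyond the scatter) and an at least 22-fold lower number from compound 3 to compound 4 (1.34 log units; beyond the scatter). Compounds 2 and 3 each give only a limit, so these steps have no upper end: the limit of > 100000 nM in this assay, at which 2 of the 4 values shown sit. The same cap also gives a 2.4-fold lower number from compound 1 to compound 4 (0.37 log units; beyond the scatter), so a carbonyl on that oxygen is not needed for a readable value.

Which of the four fluorines matter stays open, as does whether a pentafluorophenyl cap would go further.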